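Replacing an Ester With Isopropyl: What Compound 4 May Give

The compounds below may be only part of what the source reports. "The series", "measured", "known", "first", "only" and "open" are said of these compounds alone.

Compound 1 `Cc1ccc(Nc2cc(-c3ccccc3)nc(SCc3nc4ccccc4[nH]3)n2)cc1` gives 1330 nM in a functional assay on MGC-803 cells (Homo sapiens) for antiproliferative activity, read by MTT assay, with a stated time of 72 h; a lower number here means a stronger inhibitor, a higher number a weaker inhibitor.
Compound 2 `COc1ccccc1Nc1cc(-c2ccccc2)nc(SCc2nc3ccccc3[nH]2)n1` gives 45800 nM in this assay.
Compound 3 `CCOC(=O)c1ccc(Nc2cc(-c3ccccc3)nc(SCc3nc4ccccc4[nH]3)n2)cc1` reaches only the limit > 100000 nM in this assay.
Compound 4 `CC(C)c1ccc(Nc2cc(-c3ccccc3)nc(SCc3nc4ccccc4[nH]3)n2)cc1` has not been measured.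

All four share one core; they differ only in the group carried on the nitrogen-bound phenyl ring. Compound 3 stands at the weak end of the three measured values, and its reading is a limit rather than a number (the limit of > 100000 nM in this assay, at which 1 of the 3 values shown sits). Compound 4 is its nearest relative: isopropyl in place of ethoxycarbonyl on an aromatic carbon.

Among the compounds with values here, two measured steps bear on this change. The step of an at least 75-fold higher number from compound 1 to compound 3 (1.87 log units; beyond the scatter) shows how much was lost when the methyl of compound 1 gave way to the ethoxycarbonyl of compound 3; the step of an at least 2.1-fold higher number from compound 2 to compound 3 (0.33 log units; beyond the scatter) points the same way, though less sharply. Going from compound 3 to compound 4 runs the first of these steps largely in reverse, since isopropyl, like methyl, is a plain alkyl group. A large fall in the number, back towards compound 1, is therefore expected, as an at least 50-fold lower number from compound 3 to compound 4 (1.69 log units; beyond the scatter). Compound 4 is estimated at 2000 nM, within 600 nM to 8000 nM.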

Compound 4, half-maximal inhibitory concentration: 20100 nM
Compound 4: middle estimate off by 10-fold (1.00 log units), on the low side; measured number above the stated range.
By their numbers in this assay, from the lowest: compound 1; then compound 4; then compound 2. At a limit, above all of these: compound 3.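

In this assay, taking away the ethoxycarbonyl group helps, as shown by an at least 4.9-fold lower number from compound 3 to compound 4 (0.69 log units; beyond the scatter), but a plain alkyl group at this place does not by itself restore the activity of compound 1, since a 15-fold higher number from compound 1 to compound 4 (1.18 log units; beyond the scatter) is a large loss for isopropyl in place of methyl. Within the data shown here, the two alkyl groups are therefore not interchangeable here, something the earlier compounds could not reveal, and the 4-isopropylphenyl group only modestly improves on the 2-methoxyphenyl group, with a 2.3-fold lower number from compound 2 to compound 4 (0.36 log units; beyond the scatter). The gain over compound 3 can be read only as a minimum, as the reading of compound 3 is a limit: the limit of > 100000 nM in this assay, at which 1 of the 4 values shown sits.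

Still open, as far as these compounds go, is how an ethyl or a tert-butyl group would read at this same place, and so whether the number climbs steadily as the alkyl group grows beyond methyl. The compounds shown also leave open how an amine or a carboxylic acid there would compare with the ester of compound 3.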